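From fluoro to benzyloxycarbonyl on a shared core

A few compounds are considered here, and "the series" means these few. Any claim that something is new, unique, unknown or untested is made for them only; others in the source may bear on it.

Compound 1 `Fc1ccc2[nH]c(-c3cn(-c4ccccc4)nc3-c3ccccc3)nc2c1` gives 2430 nM here.
Compound 2 `COc1ccc(-c2nn(-c3ccccc3)cc2-c2nc3cc(F)ccc3[nH]2)cc1` gives 1510 nM here.

Both were measured in a functional assay on MCF7 cells (Homo sapiens) for antiproliferative activity, read by MTT assay, with a stated time of 48 h; on this read-out higher numbers stand for weaker inhibition and lower numbers for stronger inhibition. Going by the values given here, compound 2 stands level with compound 1, the only other measured compound: the step is a 1.6-fold lower number from compound 1 to compound 2 (0.21 log units; within the scatter) and no more. Compound 3 `COc1ccc(-c2nn(-c3ccccc3)cc2-c2nc3cc(C(=O)OCc4ccccc4)ccc3[nH]2)cc1` has benzyloxycarbonyl in place of fluoro, and the difference is benzyloxycarbonyl in place of fluoro on an aromatic carbon in all. Among the compounds with values here, the one measured step concerns methoxy in place of hydrogen, not this place, so no measured step bears on the change and no direction can be expected. The estimated step, a 1.2-fold higher number from compound 2 to compound 3 (0.08 log units; within the scatter), is therefore none beyond the scatter, though uncertain. Compound 3 is estimated at 1800 nM in this assay, with an expected range from 500 nM to 7000 nM overall.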

Compound 3, half-maximal inhibitory concentration: 7460 nM
Compound 3: middle estimate off by 4.1-fold (0.62 log units), on the low side, and the stated range ends below it.
By their numbers in this assay, from the lowest: compounds 2 and 1 (each within the scatter of the next); then compound 3.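

In this assay the group does matter at this place on the shared core, which the earlier pair left unchanged. Benzyloxycarbonyl in place of fluoro gives a 4.9-fold higher number from compound 2 to compound 3 (0.69 log units; beyond the scatter) and so the first step beyond the scatter. The higher number comes with a much larger group that brings a second six-membered aromatic ring, though this rests on one pair alone. No measurement shown here explains the step.

Still open, from the compounds shown here alone, is whether the step comes from the benzyl part or the carbonyl, which a carboxylic acid, a methyl ester or an amide at this place could separate. Going by these compounds, whether a small group such as chloro or hydrogen would stay level with fluoro also remains open.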